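The compounds below may be only part of what the source reports. "The series", "measured", "known", "first", "only" and "open" are said of these compounds alone.

Working notes on the series. Compound 2 `Cc1cccc(F)c1N(C)C(=O)c1ccc(-c2ccc(OS(N)(=O)=O)cc2)o1` gives 150 nM in an assay on T47D cells for inhibition of Steryl-sulfatase (Homo sapiens), read by HPLC, with a stated time of 24 h (on this read-out higher numbers stand for weaker inhibition and lower numbers for stronger inhibition), the lowest of the two numbers recorded so far. Compound 1 `Cc1cc(-c2ccc(C(=O)N(C)c3ccccc3C)o2)ccc1OS(N)(=O)=O` differs from compound 2 in more than one place. In this assay compound 1 gives 570 nM; the two values lie well beyond the usual scatter, with compound 2 on the stronger side. Compound 3 `Cc1ncccc1N(C)C(=O)c1ccc(-c2ccc(OS(N)(=O)=O)cc2)o1` is not yet measured in this assay. Relative to compound 2 it carries 2-methylpyridin-3-yl in place of 2-fluoro-6-methylphenyl on an amide-type nitrogen, the amide part otherwise unchanged. For the measured compounds named here, no measured pair in the set shares this change, so no prior step guides it. The expectation is for a small loss or a value within the scatter, with the step from compound 2 to compound 3 in this assay estimated at a 1.7-fold higher number from compound 2 to compound 3 (0.24 log units; within the scatter). Compound 3 is therefore expected near 260 nM in this assay, within a range of 100 nM to 700 nM.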

Compound 3, half-maximal inhibitory concentration: 270 nM
For compound 3 the middle estimate is 1.0-fold (0.02 log units) below the measured one; measured number inside the range.
By their numbers in this assay, from the lowest: compounds 2 and 3 (each within the scatter of the next); then compound 1.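

In this assay, the exchange on the amide-type nitrogen gives a 1.8-fold higher number from compound 2 to compound 3 (0.26 log units; within the scatter), so the two groups cannot be told apart at this place. For the compounds shown here, the first measured exchange here thus shows that a six-membered aromatic ring of carbon only, carrying fluorine, can give way to 2-methylpyridin-3-yl, a ring with 1 hetero atom and 1 hydrogen-bond acceptor, with the values remaining within the scatter of each other. No available measurement explains this result.

The fluorine and the ring nitrogen differ together in this one exchange, so their separate contributions cannot be read from compounds 2 and 3. Also open, going by these compounds, is whether a group such as cyclohexyl, a saturated ring, or 2-methoxyphenyl on the same nitrogen would stay within the scatter of compound 2.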